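Dropping the isopropoxy group from compound 1

The source may report more compounds than this note shows. Statements on the series, on what has been measured and on what is new or still open speak of the compounds shown alone.

Measured in an ADME assay on L132 cells (Homo sapiens) for cytotoxicity, read by MTT assay, with a stated time of 72 h (on this read-out higher numbers stand for weaker inhibition and lower numbers for stronger inhibition), so far:
- Compound 1 `COc1ccc(C2=C(c3cc(OC)c(OC)c(OC)c3)C(=O)C(OC(C)=O)C2)cc1OC(C)C` gives > 100 ug/mL as a limit
- Compound 2 `COc1ccc(C2=C(c3cc(OC)c(OC)c(OC)c3)C(=O)CC2C)cc1C(=O)O` gives > 100 ug/mL as a limit

Compound 1 has no exact number here, only a limit (the limit of > 100 ug/mL in this assay, at which 2 of the 2 values shown sit), and compound 2 sits at that same limit. Compound 3 `COc1ccc(C2=C(c3cc(OC)c(OC)c(OC)c3)C(=O)C(OC(C)=O)C2)cc1` changes compound 1 in one place (hydrogen in place of isopropoxy on an aromatic carbon), with hydrogen in place of isopropoxy on an aromatic carbon. Among the compounds with values here, no measured pair shows what such a change does. The expected step in this assay is a number no higher from compound 1 to compound 3 (the limit leaves the size open) and so none beyond the scatter. Compound 3 is estimated at 100 ug/mL within an expected range from 30 ug/mL to 300 ug/mL in this assay.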

Compound 3, half-maximal inhibitory concentration: > 100 ug/mL
Compound 3 gave a limit, no number (the forecaster's own chance of this, stated with the estimate: 65%); the middle value lies on the limit itself.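

Compound 1 and compound 3 each give only a limit, so no step between them can be read: the limit of > 100 ug/mL in this assay, at which 3 of the 3 values shown sit.

The compounds shown leave open what hydrogen in place of isopropoxy does in this assay.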